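The source may hold more compounds than are shown below. What is called first, only, known or untested is meant among the compounds shown, and "the series" means these compounds.

Compound 1 `Nc1nc(N)c2c(-c3ccsc3)cn([C@@H]3O[C@H](CO)[C@@H](O)[C@H]3O)c2n1` in a functional assay on K562 cells (Homo sapiens), read by MTT assay, with a stated time of 72 h (a higher number here means a weaker inhibitor, a lower number a stronger inhibitor), gives > 20000 nM, a limit of the assay rather than a number.
Compound 2 `Nc1nc(N)c2c(-c3cc4ccccc4o3)cn([C@@H]3O[C@H](CO)[C@@H](O)[C@H]3O)c2n1` in this assay gives > 20000 nM, again a limit.
Compound 3 `COc1ncnc2c1c(I)cn2[C@@H]1O[C@H](CO)[C@@H](O)[C@H]1O` in this assay gives 14800 nM.

Among the compounds with values here, compound 3 is thus the only compound with a measured number; the other two sit at the limit of > 20000 nM in this assay, at which 2 of the 3 values shown sit. Within the data shown here, the only step between measured compounds, a step that the two limits leave unreadable from compound 1 to compound 2, is unreadable because both ends are limits, and it concerns a different change. Compound 4 `C#Cc1cn([C@@H]2O[C@H](CO)[C@@H](O)[C@H]2O)c2ncnc(OC)c12` differs from compound 3 by ethynyl in place of iodo on an aromatic carbon. Among the measured compounds shown here, no measured step bears on this change, so no size or direction can be read from the data. The step of a 1.1-fold lower number from compound 3 to compound 4 (0.02 log units; within the scatter) is therefore expected to stay within the scatter. Compound 4 is estimated at 14000 nM, in the range 4000 nM to 20000 nM.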

Compound 4, half-maximal inhibitory concentration: 380 nM
Beside the measured number, compound 4's estimate is 37-fold (1.57 log units) above it; the whole stated range lies above it.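

Putting ethynyl in place of iodo on this aromatic carbon gives a 39-fold lower number from compound 3 to compound 4 (1.59 log units; beyond the scatter) in this assay. Within the data shown here, the rest of the structure is unchanged, so the group on this carbon alone can shift the number strongly, which the earlier compounds could not show, as their one step cannot be read. Nothing measured here accounts for the size of this step.

The compounds shown leave open how an amine, a carboxylic acid or a longer chain ending in a triple bond would fare on this carbon. Also open, on these data alone, is whether ethynyl would give a similar step on the core of compound 1.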